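The compounds below may be only part of what the source reports. "The series", "measured", "known", "first", "only" and "open" are said of these compounds alone.

The measured compounds are compound 1 `Cc1ccc(-c2n[nH]c(-c3ccccc3)n2)cc1` with > 20 mg/kg, compound 2 `COc1cccc(-c2n[nH]c(-c3ccc(C)cc3)n2)c1` with 7 mg/kg, and compound 3 `COc1cccc(-c2n[nH]c(-c3ccc(C)cc3C)n2)c1` with 0.04 mg/kg.

All three were tested in a functional assay on the whole organism (Cricetulus griseus) with Cricetinae gen. sp. as the target; on this read-out lower numbers stand for an effect already at smaller amounts and higher numbers for an effect only at larger amounts of compound. For compound 1 the value is only a limit of this assay, not a number (the limit of > 20 mg/kg in this assay, at which 1 of the 3 values shown sits). Compound 2 and compound 3 differ by methyl in place of hydrogen on an aromatic carbon, and this single change gave a 180-fold lower number from compound 2 to compound 3 (2.24 log units; beyond the scatter).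

Compound 4 `Cc1ccc(-c2n[nH]c(-c3ccccc3C)n2)cc1` is not yet measured. It stands to compound 1 as compound 3 stands to compound 2: the change is methyl in place of hydrogen on an aromatic carbon. The surroundings of the place are not identical, since in the pair of compound 2 and compound 3 the entering methyl is also meta to a methyl group, which is absent in compound 4, so this is the same kind of change rather than the same change. The cores of compound 1 and compound 2 differ in a way that is not broken down here.

Because compound 2 and compound 3 showed a 180-fold lower number from compound 2 to compound 3 (2.24 log units; beyond the scatter), a comparable drop is expected for compound 4, giving an at least 40-fold lower number from compound 1 to compound 4 (1.60 log units; beyond the scatter); the starting point is uncertain, since compound 1 gives only a limit. Compound 4 is therefore estimated at 0.5 mg/kg in this assay, between 0.05 mg/kg and 10 mg/kg.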

Compound 4, dose for half-maximal effect: 20 mg/kg
Beside the measured number, compound 4's estimate is 40-fold (1.60 log units) below it; the whole stated range lies below it.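

Compound 1 has only a limit of the assay, > 20 mg/kg in this assay. Compound 4 gives 20 mg/kg in this assay, which on its own shows neither a large drop on this core nor the absence of one. The data give a number no higher from compound 1 to compound 4 (the limit leaves the size open) and no readable size for this step. The result therefore does not show that methyl in place of hydrogen on an aromatic carbon carries over from one core to the other with a similar effect, and it does not show that the effect is confined to the core of compound 2: the same change on two cores in this assay, a 180-fold lower number (2.24 log units; beyond the scatter) from compound 2 to compound 3 and a number no higher (the limit leaves the size open) from compound 1 to compound 4; the limit leaves it open whether they differ.

The compounds shown leave open how an ethyl group, a chlorine atom or a methoxy group would behave in place of this methyl on either core. Also open, from the compounds shown here alone, is how far the true number of compound 1 lies from that of compound 4, and with it how the two steps compare in size.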